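Replacing the 4-phenylpiperidin-1-yl group of compound 3

The source may report more compounds than this note shows. Statements on the series, on what has been measured and on what is new or still open speak of the compounds shown alone.

In a functional assay on A549 cells (Homo sapiens) for antiproliferative activity, read by MTT assay, with a stated time of 72 h (a lower number here means a stronger inhibitor, a higher number a weaker inhibitor), compound 1 `COc1cc2c(Nc3ccc(C#N)cc3)ncnc2cc1OCCCN1CCC(C)CC1` gives 32300 nM and compound 2 `COc1cc2c(Nc3ccc(C#N)cc3)ncnc2cc1OCCCN1CCC(O)CC1` gives 29900 nM, a pair within the scatter of each other, as a 1.1-fold lower number from compound 1 to compound 2 (0.03 log units; within the scatter) shows. Compound 3 `COc1cc2c(Nc3ccc(C#N)cc3)ncnc2cc1OCCCN1CCC(c2ccccc2)CC1` has the lowest number of the three, at 9500 nM. Compound 4 `CCN1CCN(CCCOc2cc3ncnc(Nc4ccc(C#N)cc4)c3cc2OC)CC1` keeps the shared core of compound 3 but changes its end group: 4-ethylpiperazin-1-yl in place of 4-phenylpiperidin-1-yl on a saturated chain carbon, three bonds along the chain from an oxygen on an aromatic ring. Within the data shown here, no measured step covers this exact swap. The nearest guides are the modest steps that came with adding phenyl to the ring, a 3.4-fold lower number from compound 1 to compound 3 (0.53 log units; beyond the scatter) and a 3.1-fold lower number from compound 2 to compound 3 (0.50 log units; beyond the scatter). Compound 4 has no phenyl, so a step of similar size in the opposite direction is expected, a 2.6-fold higher number from compound 3 to compound 4 (0.42 log units; beyond the scatter). Compound 4 is estimated at 25000 nM, with an expected range of 10000 nM to 60000 nM.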

Compound 4, half-maximal inhibitory concentration: 16000 nM
Compound 4: the middle estimate sits 1.6-fold (0.19 log units) above what was measured; measured number inside the range.
By their numbers in this assay, from the lowest: compounds 3, 4, 2 and 1 (each within the scatter of the next, the first and the last beyond it).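

In this assay, a phenyl ring is not required at this place on the chain: 4-ethylpiperazin-1-yl, which has none, replaces 4-phenylpiperidin-1-yl with a 1.7-fold higher number from compound 3 to compound 4 (0.23 log units; within the scatter). The same group also matches 4-hydroxypiperidin-1-yl, with a 1.9-fold lower number from compound 2 to compound 4 (0.27 log units; within the scatter), and improves modestly on 4-methylpiperidin-1-yl, with a 2.0-fold lower number from compound 1 to compound 4 (0.31 log units; beyond the scatter). No measurement here explains these results.

The compounds shown leave open whether the ethyl group or the second ring nitrogen matters more. They also leave open how a morpholine ring or a longer chain would compare.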